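Fluoro for Chloro on the Styryl Ring

The compounds below may be only part of what the source reports. "The series", "measured", "known", "first", "only" and "open" are said of these compounds alone.

The measured compounds:
compound 1, `O=S(=O)(/C=C/c1ccc(F)cc1)Cc1ccc(Nc2ncnc3ccccc23)cc1`, 2000 nM
compound 2, `O=S(=O)(/C=C/c1ccc(Cl)cc1)Cc1ccc(Nc2ncnc3ccccc23)cc1`, 54000 nM
compound 3, `O=S(=O)(/C=C/c1ccc(F)cc1Cl)Cc1ccc(Nc2ncnc3cc(Cl)ccc23)cc1`, > 100000 nM

Of the compounds shown here, three have been tested in a functional assay on SK-OV-3 cells (Homo sapiens); a lower number here means a stronger inhibitor of growth, a higher number a weaker inhibitor of growth. Compound 1 and compound 2 share one core and differ in a single place: fluoro in place of chloro on an aromatic carbon. That change produced a 27-fold lower number from compound 2 to compound 1 (1.43 log units; beyond the scatter). Compound 3 carries a different core, and how it differs from the core of compound 2 is not broken down here. For compound 3 the assay reports only a limit, > 100000 nM, which is the limit of > 100000 nM in this assay, at which 1 of the 3 values shown sits.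

Compound 4, `O=S(=O)(/C=C/c1ccc(F)cc1F)Cc1ccc(Nc2ncnc3cc(Cl)ccc23)cc1`, has not yet been measured. It differs from compound 3 in one place: fluoro in place of chloro on an aromatic carbon. Among the measured compounds shown here, this is the same kind of change as the one between compound 2 and compound 1, but not the same change: in compound 2 the chloro that leaves sits para to a large group, whereas in compound 3 it sits ortho to a large group and meta to a fluoro group, and the two cores differ as well. Because the same kind of change gave a 27-fold lower number from compound 2 to compound 1 (1.43 log units; beyond the scatter), a measurable number is expected for compound 4 in this assay, though the starting point is only a limit, so the size is uncertain. The step expected here is an at least 3.3-fold lower number from compound 3 to compound 4 (0.52 log units; beyond the scatter). Compound 4 is estimated to give 30000 nM, most likely between 5000 nM and 150000 nM.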

Compound 4, concentration for 50% growth inhibition: > 100000 nM
Compound 4: a limit, no number (the forecaster's own chance of this, stated with the estimate: 35%); middle value at least 3.3-fold (0.52 log units) from the limit.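

In this assay compound 4 gives > 100000 nM, which is a limit and not a number. Compound 3 also stands at a limit, so no step between compound 3 and compound 4 can be read: the limit of > 100000 nM in this assay, at which 2 of the 4 values shown sit.

The compounds shown leave open whether going from 2-chloro-4-fluorophenyl to 2,4-difluorophenyl changes growth inhibition at all, and whether fluoro in place of chloro does on this core what it does between compound 2 and compound 1.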